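Benzyl ring swap on the shared core

The source may report more compounds than this note shows. Statements on the series, on what has been measured and on what is new or still open speak of the compounds shown alone.

Measured so far in a functional assay on MGC-803 cells (Homo sapiens) for inhibition, read by MTT assay, with a stated time of 72 h; on this read-out higher numbers stand for weaker inhibition and lower numbers for stronger inhibition:
compound 1 `N#Cc1c(Nc2ccc(Cl)cc2)nc(SCc2cn(Cc3ccccc3Cl)nn2)nc1-c1ccccc1`: 5850 nM
compound 2 `Cc1ccc(Cn2cc(CSc3nc(Nc4ccc(C)cc4)c(C#N)c(-c4ccccc4)n3)nn2)cc1`: > 64000 nM

Compound 2 gives only a limit in this assay, (the limit of > 64000 nM in this assay, at which 1 of the 2 values shown sits). Compound 3 `Cc1ccc(Nc2nc(SCc3cn(Cc4ccccc4Cl)nn3)nc(-c3ccccc3)c2C#N)cc1` is not yet measured; it carries 2-chlorophenyl in place of 4-methylphenyl on a saturated chain carbon bound to an aromatic nitrogen. Within the data shown here, no measured step connects these two, and compound 1, which also carries the 2-chlorobenzyl group, gives 5850 nM. The step from compound 2 to compound 3 is therefore expected to run toward stronger inhibition, beyond the scatter, as an at least 4.2-fold lower number from compound 2 to compound 3 (0.63 log units; beyond the scatter). Compound 3 is estimated at 15000 nM, within 4000 nM to 60000 nM.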

Compound 3, half-maximal inhibitory concentration: 7190 nM
Beside the measured number, compound 3's estimate is 2.1-fold (0.32 log units) above it; measured number inside the range.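

In this assay, 2-chlorobenzyl in place of 4-methylbenzyl on the shared core gives an at least 8.9-fold lower number from compound 2 to compound 3 (0.94 log units; beyond the scatter), the first single change shown to move this read-out beyond the scatter. Compound 2 stands at a limit, so this step has only a bound: the limit of > 64000 nM in this assay, at which 1 of the 3 values shown sits. With 2-chlorobenzyl kept, methyl in place of chloro on an aromatic carbon gives a 1.2-fold higher number from compound 1 to compound 3 (0.09 log units; within the scatter), so that second change does not separate the two compounds.

As far as these compounds go, it remains open whether the step follows from gaining the chloro group or from losing the methyl group. A plain benzyl group or a longer chain such as phenethyl in this place would help separate the two readings.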